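The source may hold more compounds than are shown below. What is called first, only, known or untested is meant among the compounds shown, and "the series" means these compounds.

In an ADME assay on the whole organism (Mus musculus, strain CD-1) for pharmacokinetics (on this read-out higher numbers stand for fast clearance and lower numbers for slow clearance), three compounds have been measured. Compound 1 `COc1cc([C@](O)(CCN(C)C)[C@@H](c2cc3cc(Br)ccc3nc2OC)c2cccc(OC)c2F)cc(SC)n1` gives 13 mL/min/kg, compound 2 `COc1cc([C@](O)(CCN(C)C)[C@@H](c2cc3cc(C#N)ccc3nc2OC)c2cccc(OC)c2F)cc(SC)n1` gives 42 mL/min/kg, and compound 3 `CCOc1cc([C@](O)(CCN(C)C)[C@@H](c2cc3cc(Br)ccc3nc2OC)c2ccnc(OC)c2OC)cc(OC(C)C)n1` gives 3.1 mL/min/kg, so compound 2 stands highest of the three. Compound 4 `CCSc1cc([C@](O)(CCN(C)C)[C@@H](c2cc3cc(C#N)ccc3nc2OC)c2cccc(OC)c2F)cc(SCC)n1` keeps the rest of compound 2 but carries a group of 12 heavy atoms (9 carbon, 1 nitrogen, 2 sulfur; one six-membered aromatic ring with 1 hetero atom) in place of a group of 10 heavy atoms (7 carbon, 1 nitrogen, 1 oxygen, 1 sulfur; one six-membered aromatic ring with 1 hetero atom), on a saturated chain carbon bound to an oxygen on a saturated carbon and two saturated chain carbons. For the measured compounds named here, the only measured step, a 3.2-fold higher number from compound 1 to compound 2 (0.51 log units; beyond the scatter), is cyano in place of bromo on an aromatic carbon, and it does not touch this place. Compound 3 differs from compound 2 in several places, so its value isolates no single change. No step beyond the scatter is therefore expected in this assay, and the estimated change is a 1.1-fold higher number from compound 2 to compound 4 (0.03 log units; within the scatter). For compound 4 the expected clearance is 45 mL/min/kg, with an estimated range of 18 mL/min/kg to 110 mL/min/kg.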

Compound 4, clearance: 29 mL/min/kg
Estimate against measurement, compound 4: 1.6-fold (0.19 log units) above, within the range that was stated.
By their numbers in this assay, from the lowest: compound 3; then compound 1; then compounds 4 and 2 (each within the scatter of the next).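

In this assay, for the compounds shown here, the first reading at this place, on a saturated chain carbon bound to an oxygen on a saturated carbon and two saturated chain carbons, is a 1.4-fold lower number from compound 2 to compound 4 (0.16 log units; within the scatter). Here a group of 12 heavy atoms with 2 sulfur and no oxygen replaces a group of 10 heavy atoms with 1 oxygen and 1 sulfur, and the clearance stays within the scatter. Nothing measured here explains this result. From the compounds shown here alone, whether a ring carrying a carboxylic acid or a primary amine would also stay within the scatter remains open. So does whether this exchange would behave alike with the bromo of compound 1.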